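This account rests on a few compounds, and the source may have more. Where it says the series, first, only, none or still open, it means among the compounds named here.

Three compounds have so far been measured in a functional assay on UACC-257 cells (Homo sapiens) for cytotoxicity, read by sulforhodamine B assay, with a stated time of 48 h, tested at 0.01 uM; a higher number here means a weaker effect of the compound at the concentration tested, a lower number a stronger effect:

Compound 1, `COc1ccc(-c2cc(/C=C/C(=O)c3ccc(N)cc3)[nH]n2)cc1`, gives 96%.
Compound 2, `COc1ccc(-c2cc(/C=C/C(=O)c3ccc(N)cc3)[nH]n2)cc1OC`, gives 90%.
Compound 3, `COc1cc(C(=O)/C=C/c2cc(-c3cc(OC)c(OC)c(OC)c3)n[nH]2)cc(OC)c1OC`, gives 94%.

All three numbers lie close together, and none of the pairwise gaps exceeds the usual scatter of this kind of measurement. Compound 2 and compound 1 differ in one place, (hydrogen in place of methoxy on an aromatic carbon), and the step they show in this assay is a number 6 percentage points higher from compound 2 to compound 1 (within the scatter). Compound 3 carries a different core from compound 2; the difference between the two cores is not broken down here. What can be said is that compound 3 and compound 2 give numbers that sit within the scatter of each other, as do compound 3 and compound 1.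

The unmeasured compound 4, `COc1ccc(-c2cc(/C=C/C(=O)c3cc(OC)c(OC)c(OC)c3)[nH]n2)cc1OC`, stands to compound 3 as compound 1 stands to compound 2: the change is hydrogen in place of methoxy on an aromatic carbon. Among the measured compounds shown here, it is the same kind of change as the one from compound 2 to compound 1, though the surroundings are not identical: in compound 3 the carbon that loses its methoxy is also meta to a methoxy group, which is not the case in compound 2. Given that the earlier step was a number 6 percentage points higher from compound 2 to compound 1 (within the scatter), the step from compound 3 to compound 4 in this assay is expected to be small as well, about a number 2 percentage points higher from compound 3 to compound 4 (within the scatter). Compound 4 is therefore estimated to give 96% in this assay, with a range from 88% to 102%.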

Compound 4, a percentage reported as activity, at one concentration (the size of the read-out at that concentration, not a potency): 96%
Beside the measured number, compound 4's estimate shows no gap at the digits printed, within the range that was stated.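

In this assay, the step for hydrogen in place of methoxy on an aromatic carbon is a number 2 percentage points higher from compound 3 to compound 4 (within the scatter), and set beside the earlier case, the change behaves alike on the two cores: the same change on two cores in this assay, a number 6 percentage points higher (within the scatter) from compound 2 to compound 1 and a number 2 percentage points higher (within the scatter) from compound 3 to compound 4, 4 percentage points apart, within the scatter of two such steps
Within this small set, then, nothing indicates that the core alters what this change does in this assay, and on both cores the loss of the methoxy leaves the number within the scatter. This does not show that the change has any real effect, nor that it would carry over to other cores, as it rests on two pairs of compounds and a read-out at a single concentration, which is not a potency.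

The compounds shown leave open whether a different group in place of that methoxy, such as a hydroxyl, a fluorine atom or a carboxylic acid, would take the number beyond the scatter on either core. They also leave open whether the two cores would respond to this change in the same way at other concentrations, where the size of the read-out might differ.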